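Furan-2-yl replaced in a mostly inactive series

The compounds below may be only part of what the source reports. "The series", "measured", "known", "first", "only" and "open" are said of these compounds alone.

Measured so far:
compound 1 `COc1cc(/C=C/C(=O)/C=C/c2cccc3ccccc23)ccc1OCc1cn(CCOc2cc(=O)oc3ccccc23)nn1`: 20%
compound 2 `COc1cc(/C=C/C(=O)/C=C/c2ccco2)ccc1OCc1cn(CCCOc2cc(=O)oc3ccccc23)nn1`: "not active" (no number reported)
compound 3 `COc1cc(/C=C/C(=O)/C=C/c2ccco2)ccc1OCc1cn(CCCCCOc2cc(=O)oc3ccccc23)nn1`: "not active" (no number reported)

In a functional assay on PC-3 cells (Homo sapiens) for inhibition, read by sulforhodamine B assay, with a stated time of 48 h, tested at 50 uM (a higher number here means more inhibition of growth at the concentration tested, a lower number less inhibition of growth), compound 2 has no single number, being reported as "not active" (no number reported). Compound 3 is also without a number, at "not active" (no number reported). Only compound 1 gives a number, 20%.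

Compound 4 `COc1cc(/C=C/C(=O)/C=C/c2cc(OC)c(OC)c(OC)c2)ccc1OCc1cn(CCCOc2cc(=O)oc3ccccc23)nn1` has not yet been measured. The structural change is 3,4,5-trimethoxyphenyl in place of furan-2-yl on a double-bonded chain carbon bound to a double-bonded chain carbon, with 3,4,5-trimethoxyphenyl in place of furan-2-yl. Among the compounds with values here, no measured pair shows this change, so its size in this assay is uncertain. A modest rise in inhibition is expected, towards the level of compound 1 at 20%, though a second "not active" result remains possible. For compound 4 the estimated value is 18%, with an expected range of 5% to 38%.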

Compound 4, percent growth inhibition at one concentration: 12%
The estimate for compound 4 lay 6 percentage points above the measured number; the measured number falls inside the stated range.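

Compound 4 at 12% and compound 2 at "not active" (no number reported) yield no readable step, as compound 2 has no single number. The compounds shown leave open how far 3,4,5-trimethoxyphenyl in place of furan-2-yl shifts growth inhibition. No available evidence bears on this result.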